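A Trimethoxyphenyl Swap After Three Level Results

The source may report more compounds than this note shows. Statements on the series, on what has been measured and on what is new or still open speak of the compounds shown alone.

In a functional assay on HepG2 cells (Homo sapiens) for cytotoxicity, read by MTT assay, with a stated time of 72 h (a lower number here means a stronger inhibitor, a higher number a weaker inhibitor), compound 1 (`N#Cc1ccc(/C=N/NC(=O)Nc2cc3c(Nc4ccc(F)c(Cl)c4)ncnc3cc2O[C@H]2CCOC2)cc1`) gives 26400 nM and compound 2 (`O=C(N/N=C/c1ccc(F)cc1Cl)Nc1cc2c(Nc3ccc(F)c(Cl)c3)ncnc2cc1O[C@H]1CCOC1`) gives 26100 nM while compound 3 (`O=C(N/N=C/c1cccc(Cl)c1Cl)Nc1cc2c(Nc3ccc(F)c(Cl)c3)ncnc2cc1O[C@H]1CCOC1`) gives 16900 nM and so stands level with both. The step of a 1.0-fold lower number from compound 1 to compound 2 (0.00 log units; within the scatter) stays within the scatter, and each measured step swaps one substituted phenyl group for another on a carbon with a double bond to nitrogen. Compound 4 (`COc1cc(/C=N/NC(=O)Nc2cc3c(Nc4ccc(F)c(Cl)c4)ncnc3cc2O[C@H]2CCOC2)cc(OC)c1OC`) puts 3,4,5-trimethoxyphenyl in place of 2,3-dichlorophenyl on that same carbon (3,4,5-trimethoxyphenyl in place of 2,3-dichlorophenyl on a carbon with a double bond to nitrogen). For the measured compounds named here, no measured compound carries this new group, so the guide is loose. With a 1.6-fold lower number from compound 1 to compound 3 (0.19 log units; within the scatter) and a 1.5-fold lower number from compound 2 to compound 3 (0.19 log units; within the scatter) both within the scatter, no step beyond the scatter is expected in this assay for this change. The estimated step is a 1.3-fold higher number from compound 3 to compound 4 (0.11 log units; within the scatter) and it is expected to stay small. For compound 4 the estimated value is 22000 nM with an expected range from 9000 nM to 50000 nM in this measurement.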

Compound 4, half-maximal inhibitory concentration: 31200 nM
Compound 4: middle estimate off by 1.4-fold (0.15 log units), on the low side; the measured number falls inside the stated range.
By their numbers in this assay, from the lowest: compounds 3, 2, 1 and 4 (each within the scatter of the next).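

With a 1.8-fold higher number from compound 3 to compound 4 (0.27 log units; within the scatter) and a 1.2-fold higher number from compound 2 to compound 4 (0.08 log units; within the scatter) and also a 1.2-fold higher number from compound 1 to compound 4 (0.07 log units; within the scatter) in this assay this position has now taken 3,4,5-trimethoxyphenyl, a group with oxygen atoms and more heavy atoms, without any step leaving the scatter. The earlier compounds had shown this only among phenyl groups carrying chlorine, fluorine or a nitrile. No evidence here says why the results stay so level. As far as these compounds go, whether an amine or a carboxylic acid on the phenyl ring, or a longer chain in its place, moves the number beyond the scatter remains open.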